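Trifluoromethyl in place of ethyl on the pyrimidine-bearing core

The source may report more compounds than this note shows. Statements on the series, on what has been measured and on what is new or still open speak of the compounds shown alone.

Compound 1 `Fc1cc2nc(-c3cncnc3)n(C3CC3)c2cc1F` carries hydrogen at the position in question and gives 98% in an ADME assay on microsomes from liver (Macaca fascicularis) for metabolic stability, read by LC-MS, with a stated time of 65 min, tested at 1 uM; on this read-out higher numbers stand for a more stable compound and lower numbers for a less stable compound. Compound 2 `CCc1ncncc1-c1nc2cc(F)c(F)cc2n1C1CC1` carries ethyl there and gives 78% in this assay; compound 3 `N#Cc1ncncc1-c1nc2cc(F)c(F)cc2n1C1CC1` carries cyano and gives 85% in this assay. Compound 2 has the lowest of the three numbers: the step of a number 20 percentage points lower from compound 1 to compound 2 (beyond the scatter) lies beyond the scatter, while the step of a number 7 percentage points higher from compound 2 to compound 3 (within the scatter) lies within it, so compound 2 and compound 3 are not separated.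

Compound 4 `Fc1cc2nc(-c3cncnc3C(F)(F)F)n(C3CC3)c2cc1F` differs from compound 2 by trifluoromethyl in place of ethyl on an aromatic carbon. Within the data shown here, no measured step involves trifluoromethyl, so the nearest guidance is the pair of steps a number 20 percentage points lower from compound 1 to compound 2 (beyond the scatter) and a number 13 percentage points lower from compound 1 to compound 3 (beyond the scatter), both modest, and the exchange of one substituent for another in a number 7 percentage points higher from compound 2 to compound 3 (within the scatter), which stayed within the scatter. A change of similar size is therefore expected here, with no clear direction beyond the scatter; compound 4 is estimated at 84%, in the range 70% to 96%, meaning a step of a number 6 percentage points higher from compound 2 to compound 4 (within the scatter).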

Compound 4, percent of the compound remaining: 99%
The estimate for compound 4 lay 15 percentage points below the measured number, and the stated range ends below it.
By their numbers in this assay, from the lowest: compounds 2 and 3 (each within the scatter of the next); then compounds 1 and 4 (each within the scatter of the next).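

Trifluoromethyl shows that a group at this position need not lower the number in this assay: the step with hydrogen replaced is a number 1 percentage points higher from compound 1 to compound 4 (within the scatter), whereas ethyl and cyano each stood beyond the scatter from hydrogen. The outcome therefore depends on which group sits here, with the exchange of ethyl giving a number 21 percentage points higher from compound 2 to compound 4 (beyond the scatter) and the exchange of cyano giving a number 14 percentage points higher from compound 3 to compound 4 (beyond the scatter) and thereby separating the two groups from trifluoromethyl. Nothing at hand accounts for this difference between the groups.

The compounds shown leave open how an amine, a carboxylic acid or a longer chain at this place would read out. They also leave open whether the step from ethyl to trifluoromethyl would carry over to a core changed elsewhere.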